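The source may report more compounds than this note shows. Statements on the series, on what has been measured and on what is new or still open speak of the compounds shown alone.

Measured in an assay on isolated protein (strain Sprague-Dawley) for inhibition of Amine oxidase [flavin-containing] A (Rattus norvegicus), read by spectrophotometry, with a stated time of 5 min, tested at 10 uM; a lower number here means less inhibition, a higher number more inhibition at the concentration tested (going by the name of the read-out):
compound 1 `CCOC(=O)COc1cc(=O)oc2cc(OCc3cccc(Cl)c3)ccc12` gives 0%;
compound 2 `O=C(O)COc1cc(=O)oc2cc(OCc3cccc(Cl)c3)ccc12` gives 0%;
compound 3 `O=C(COc1cc(=O)oc2cc(OCc3cccc(Cl)c3)ccc12)N1CCCCC1` gives 9%.

Compound 3 holds the highest of the three numbers, yet the scatter does not set it apart from compound 1 or compound 2. Compound 4 `N#Cc1cc(=O)oc2cc(OCc3cccc(Cl)c3)ccc12` differs from compound 3 in one place: cyano in place of ((piperidin-1-yl)carbonyl)methoxy on an aromatic carbon. The measured steps all alter the group on the carbonyl carbon of that same side chain: no change at the digits printed from compound 1 to compound 2 (within the scatter), a number 9 percentage points higher from compound 1 to compound 3 (within the scatter) and a number 9 percentage points higher from compound 2 to compound 3 (within the scatter). None of them removes the whole side chain or brings in a cyano group, so they bear only loosely on this step. Nothing in them points to a change beyond the scatter, and the expected step is a number 4 percentage points lower from compound 3 to compound 4 (within the scatter). Compound 4 is therefore estimated at 5%, between 0% and 20%.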

Compound 4, a percentage reported as inhibition, at one concentration (the size of the read-out at that concentration, not a potency): 23%
Estimate against measurement, compound 4: 18 percentage points below; the measured number lies above the stated range.
By their numbers in this assay, from the lowest: compounds 1, 2 and 3 (each within the scatter of the next); then compound 4.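

Replacing the whole side chain with cyano at this aromatic carbon, opposite the ring oxygen, shifts the number in this assay beyond the scatter, which no change at the carbonyl end of the chain did. The step reads a number 14 percentage points higher from compound 3 to compound 4 (beyond the scatter) and a number 23 percentage points higher from compound 2 to compound 4 (beyond the scatter) and also a number 23 percentage points higher from compound 1 to compound 4 (beyond the scatter) in the same direction. Nothing shown explains this rise. As far as these compounds go, whether it comes from cyano itself or simply from losing the side chain stays open. A hydrogen or a methyl group at this carbon would help separate those two readings.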